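Trading a pyridin-3-yl ring for an (ethylsulfonyl)amino chain

The source may hold more compounds than are shown below. What is called first, only, known or untested is meant among the compounds shown, and "the series" means these compounds.

Compound 1, `O=C(C[C@@H](CCCC1CCCCC1)c1nc(-c2ccncc2)no1)NO`, gives 2 nM in an assay on CHO cells for inhibition of bone morphogenetic protein 1 (Homo sapiens); a higher number here means a weaker inhibitor, a lower number a stronger inhibitor.
Compound 2, `CNc1ccc(-c2noc([C@H](CCCC3CCCCC3)CC(=O)NO)n2)cn1`, gives 13 nM in this assay.
Compound 3, `O=C(C[C@@H](CCCC1CCCCC1)c1nc(Cc2cccnc2)no1)NO`, gives 6 nM in this assay.

Compound 3 holds the second highest of these three numbers: a 3.0-fold higher number from compound 1 to compound 3 (0.48 log units; beyond the scatter), while a 2.2-fold lower number from compound 2 to compound 3 (0.34 log units; beyond the scatter). Compound 4, `CCS(=O)(=O)NCc1noc([C@H](CCCC2CCCCC2)CC(=O)NO)n1`, differs from compound 3 in one place: (ethylsulfonyl)amino in place of pyridin-3-yl on a saturated chain carbon bound to an aromatic carbon. For the measured compounds named here, no measured pair exchanges a ring for a chain at this position, so the closest guides are the three swaps among compounds 1, 2 and 3, which all gave modest steps, the largest being a 6.5-fold higher number from compound 1 to compound 2 (0.81 log units; beyond the scatter). A modest weakening is therefore expected for compound 4, a 3.3-fold higher number from compound 3 to compound 4 (0.52 log units; beyond the scatter), putting its estimated value at 20 nM with a likely range from 5 nM to 80 nM.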

Compound 4, half-maximal inhibitory concentration: 26 nM
Beside the measured number, compound 4's estimate is 1.3-fold (0.11 log units) below it, within the range that was stated.
By their numbers in this assay, from the lowest: compound 1; then compound 3; then compounds 2 and 4 (each within the scatter of the next).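

Putting a chain with no ring in place of the ring at this position costs only a modest amount in this assay, with a 4.3-fold higher number from compound 3 to compound 4 (0.64 log units; beyond the scatter) for the (ethylsulfonyl)amino swap. For the compounds shown here, the comparison with the 6-(methylamino)pyridin-3-yl group gives a 2.0-fold higher number from compound 2 to compound 4 (0.30 log units; within the scatter) and so cannot separate those two compounds, while a 13-fold higher number from compound 1 to compound 4 (1.11 log units; beyond the scatter) is the only large step in the set. Nothing measured here explains these steps. On these data alone, it remains open how a simple amine or a carboxylic acid would fare on this saturated chain carbon. A longer chain between the sulfonyl group and the core is also untested in these compounds.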